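Swapping the aryl group on the pyridazinone nitrogen

The source may hold more compounds than are shown below. What is called first, only, known or untested is meant among the compounds shown, and "the series" means these compounds.

Of the compounds shown here, two have been measured in a functional assay on MCF7 cells (Homo sapiens) for cytotoxicity, read by MTT assay, with a stated time of 72 h; on this read-out lower numbers stand for stronger inhibition and higher numbers for weaker inhibition. Compound 1 `COc1ccc(-n2ccc(=O)c(C(=O)Nc3ccc(Oc4ccnc5[nH]ccc45)cc3)n2)cc1` gives 21600 nM in this assay. Compound 2 `Cc1cc(=O)n(-c2ccc(F)cc2)nc1C(=O)Nc1ccc(Oc2ncnc3[nH]ccc23)cc1` gives 4800 nM in this assay, the lower of the two numbers; the gap from compound 1 lies beyond the scatter of this measurement, so compound 2 stands as the stronger of the two. Compound 3 `Cc1cc(=O)n(-c2ccccc2OC(F)(F)F)nc1C(=O)Nc1ccc(Oc2ncnc3[nH]ccc23)cc1` has not yet been measured. It keeps the whole of compound 2 except for one change: 2-(trifluoromethoxy)phenyl in place of 4-fluorophenyl on an aromatic nitrogen. Among the compounds with values here, no measured pair in this set isolates such a change, so there is nothing here to say how this assay responds to it, and the direction of the step remains open. The expectation for compound 3 is therefore a step of a 1.4-fold higher number from compound 2 to compound 3 (0.13 log units; within the scatter) that is small and may fall within the scatter, with a somewhat weaker result held as the more likely side. On that basis compound 3 is estimated at 6500 nM in this assay, within a range from 2000 nM to 22000 nM.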

Compound 3, half-maximal inhibitory concentration: 32000 nM
Beside the measured number, compound 3's estimate is 4.9-fold (0.69 log units) below it, outside the stated range (above it).
By their numbers in this assay, from the lowest: compound 2; then compounds 1 and 3 (each within the scatter of the next).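

In this assay, putting 2-(trifluoromethoxy)phenyl in place of 4-fluorophenyl on the aromatic nitrogen gives a 6.7-fold higher number from compound 2 to compound 3 (0.82 log units; beyond the scatter) and so moves the result towards weaker inhibition. Within the data shown here, this is the first pair in the set that differs in one place, and it shows that the aryl group on this nitrogen is not a silent part of the molecule: with everything else in compound 2 kept, this single exchange carries the number beyond the scatter. Nothing at hand accounts for the size or the direction of this step.

On these data alone, whether the loss belongs to the trifluoromethoxy group itself or to where it sits on the phenyl ring stays open, since the fluorine and its place are given up together in this one exchange. The compounds shown also do not tell how this assay would answer to an amine, a carboxylic acid or a longer alkyl chain on that phenyl ring, so a single step marks out only one direction at this position.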